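This account rests on a few compounds, and the source may have more. Where it says the series, first, only, none or still open, it means among the compounds named here.

In a functional assay on B16-F10 cells (Homo sapiens) for cytotoxicity against B16-F10 (Mus musculus), read by MTT assay, with a stated time of 72 h (a higher number here means that more compound is needed for the effect, a lower number that less compound is needed), the measured compounds stand as follows.
Compound 1 `O=C1/C(=C\c2cccc(Oc3ccccc3)c2)c2ccccc2N1c1c(Cl)cccc1Cl`: > 100 ug/mL, a limit of the assay.
Compound 2 `O=C1/C(=C\c2ccc(F)cc2)c2ccccc2N1c1c(Cl)cccc1Cl`: 38 ug/mL.

Within the data shown here, compound 2 holds the only actual number in this assay; the other value shown is a limit, (the limit of > 100 ug/mL in this assay, at which 1 of the 2 values shown sits), so no measured step between two numbers exists to lean on. Compound 3 `O=C1/C(=C\c2ccccc2Cl)c2ccccc2N1c1c(Cl)cccc1Cl` keeps the shared core of compound 2 and differs from it in one place: 2-chlorophenyl in place of 4-fluorophenyl on a double-bonded chain carbon bound to a double-bonded ring carbon. Among the measured compounds shown here, with no measured step of this kind to compare against, the expected change from compound 2 to compound 3 in this assay is a 1.1-fold higher number from compound 2 to compound 3 (0.02 log units; within the scatter), which is taken to lie within the usual scatter rather than beyond it. Compound 3 is therefore estimated to give 40 ug/mL in this assay, with a plausible range from 15 ug/mL to 100 ug/mL.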

Compound 3, concentration for half-maximal effect: 39 ug/mL
Beside the measured number, compound 3's estimate is 1.0-fold (0.01 log units) above it; the range from low to high includes it.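

In this assay, among these compounds, the exchange of 4-fluorophenyl for 2-chlorophenyl gives a 1.0-fold higher number from compound 2 to compound 3 (0.01 log units; within the scatter), the only step between two actual numbers at this place, on a double-bonded chain carbon bound to a double-bonded ring carbon. At this position, then, the two groups cannot be told apart in this read-out, even though they carry different halogens. Nothing measured here accounts for this result.

The compounds shown leave open whether a phenyl ring bearing an amine or a carboxylic acid at this place would move the number beyond the scatter. They also leave open whether a smaller group, such as a methyl, would read the same as these two phenyl groups.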